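The source may hold more compounds than are shown below. What is called first, only, known or untested is meant among the compounds shown, and "the series" means these compounds.

Compound 1, `COc1cc(/C=C/C(=O)C2=C(/C=C/c3ccc(O)c(OC)c3)NC(=O)NC2c2ccc(N(C)C)cc2)ccc1O`, gives 12500 nM in a functional assay on HCT-116 cells (Homo sapiens) for cytotoxicity, read by MTT assay, with a stated time of 48 h; a lower number here means a stronger inhibitor, a higher number a weaker inhibitor. Compound 2, `COc1cc(/C=C/C(=O)C2=C(/C=C/c3ccc(O)c(OC)c3)NC(=O)NC2c2c(Cl)cccc2Cl)ccc1O`, gives 50000 nM. Compound 3, `COc1cc(/C=C/C(=O)C2=C(/C=C/c3ccc(O)c(OC)c3)NC(=S)NC2c2ccc(N(C)C)cc2)ccc1O`, gives 12500 nM.

The change from compound 1 to compound 2 is 2,6-dichlorophenyl in place of 4-(dimethylamino)phenyl on a saturated ring carbon, on a saturated ring carbon, and it made a 4.0-fold higher number from compound 1 to compound 2 (0.60 log units; beyond the scatter). Compound 3 carries a different core from compound 1; the difference between the two cores is not broken down here, and in this assay compound 3 stands level with compound 1. Compound 4, `COc1cc(/C=C/C(=O)C2=C(/C=C/c3ccc(O)c(OC)c3)NC(=S)NC2c2c(Cl)cccc2Cl)ccc1O`, has not yet been measured. It differs from compound 3 by 2,6-dichlorophenyl in place of 4-(dimethylamino)phenyl on a saturated ring carbon, the same change at the same place. Because that change earlier made a 4.0-fold higher number from compound 1 to compound 2 (0.60 log units; beyond the scatter), a step of similar size is expected here, namely a 4.0-fold higher number from compound 3 to compound 4 (0.60 log units; beyond the scatter). Compound 4 is therefore estimated at 50000 nM, expected to fall between 20000 nM and 120000 nM.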

Compound 4, half-maximal inhibitory concentration: 50000 nM
Beside the measured number, compound 4's estimate shows no gap at the digits printed, within the range that was stated.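

In this assay, putting 2,6-dichlorophenyl in place of 4-(dimethylamino)phenyl on the saturated ring carbon gave a 4.0-fold higher number from compound 3 to compound 4 (0.60 log units; beyond the scatter). The step on the core of compound 3 matches the one on the core of compound 1, so here the change carried over from one core to the other: the same change on two cores in this assay, a 4.0-fold higher number (0.60 log units; beyond the scatter) from compound 1 to compound 2 and a 4.0-fold higher number (0.60 log units; beyond the scatter) from compound 3 to compound 4, 1.0-fold (0.00 log units) apart, within the scatter of two such steps. For the compounds shown here, this rests on only two pairs in one cell assay, and it shows neither why the number rises nor that the change would act alike on any further core.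

The compounds shown leave open how a plain phenyl, a pyridine ring or a carboxylic acid would fare on that saturated ring carbon. They also leave open what happens when the 2-(4-hydroxy-3-methoxyphenyl)ethenyl group is changed.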